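The compounds below may be only part of what the source reports. "The series", "measured", "known", "first", "only" and "open" are said of these compounds alone.

Measured compounds:
compound 1, `COc1cc2nc(/C=C/c3cccnc3)nc(N3CCC(CCNS(N)(=O)=O)CC3)c2cc1OC` — 58 nM
compound 2, `COc1cc2nc(/C=C/c3ccc(F)cc3)nc(N3CCC(CCNS(N)(=O)=O)CC3)c2cc1OC` — 465 nM

Of the compounds shown here, two have been measured in an assay on cells for inhibition of Ectonucleotide pyrophosphatase/phosphodiesterase family member 1 (Homo sapiens), with a stated time of 60 min; on this read-out higher numbers stand for weaker inhibition and lower numbers for stronger inhibition. Compound 1 `COc1cc2nc(/C=C/c3cccnc3)nc(N3CCC(CCNS(N)(=O)=O)CC3)c2cc1OC` gives 58 nM, and compound 2 `COc1cc2nc(/C=C/c3ccc(F)cc3)nc(N3CCC(CCNS(N)(=O)=O)CC3)c2cc1OC` gives 465 nM. Compound 2 therefore stands at the highest number of the two, with compound 1 as its nearest neighbour at a clearly lower number; this gap is an 8.0-fold higher number from compound 1 to compound 2 (0.90 log units; beyond the scatter), which arises from 4-fluorophenyl in place of pyridin-3-yl on a double-bonded chain carbon bound to a double-bonded chain carbon.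

Compound 3 `COc1cccc(/C=C/c2nc(N3CCC(CCNS(N)(=O)=O)CC3)c3cc(OC)c(OC)cc3n2)c1` is not yet measured. It differs from compound 2 by 3-methoxyphenyl in place of 4-fluorophenyl on a double-bonded chain carbon bound to a double-bonded chain carbon. Among the compounds with values here, the only measured step that bears on this position is the one from compound 1 to compound 2, which showed that exchanging the aryl group here can shift this assay by a modest amount. That step compared a group with one acceptor against one without; the present change again brings in one acceptor, but on a ring of carbon only, so the measured step is a loose guide at best.

In this assay compound 3 is expected to land near compound 2, with a small improvement as the more likely direction: an estimated 300 nM, within 100 nM to 900 nM, meaning an expected 1.6-fold lower number from compound 2 to compound 3 (0.19 log units; within the scatter).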

Compound 3, inhibition constant: 101 nM
Beside the measured number, compound 3's estimate is 3.0-fold (0.47 log units) above it; the range from low to high includes it.
By their numbers in this assay, from the lowest: compounds 1 and 3 (each within the scatter of the next); then compound 2.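

In this assay, 3-methoxyphenyl in place of 4-fluorophenyl on a double-bonded chain carbon bound to a double-bonded chain carbon gives a 4.6-fold lower number from compound 2 to compound 3 (0.66 log units; beyond the scatter) and so shows that a ring of carbon only can carry a low number at this position, which the earlier pair could not show. The comparison with the pyridin-3-yl group gives a 1.7-fold higher number from compound 1 to compound 3 (0.24 log units; within the scatter) and sets these two groups level within the scatter, leaving compound 2 apart from both; among these compounds, a ring nitrogen is therefore not needed for the lower number, and the two groups counted with a hydrogen-bond acceptor both stand below 4-fluorophenyl, with no compound going against this. Nothing at hand explains why the number moves with these groups.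

The fluorine and the methoxy group differ in both identity and ring position, so the result cannot separate these two changes; 3-fluorophenyl and 4-methoxyphenyl would be the groups that pull them apart. Also open, from the compounds shown here alone, is how this position responds to a group of another kind, such as a carboxylic acid or a dimethylamino group on the ring, or to a longer chain in place of the double-bonded one.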